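Notes on a diaryl urea series with a shared core

The source may report more compounds than this note shows. Statements on the series, on what has been measured and on what is new or still open speak of the compounds shown alone.

Compound 2 `COc1ccc(NC(=O)Nc2cccc(CNc3ncnc4cc(OC)c(OC)cc34)c2)cc1` gives 24500 nM in a functional assay on A549 cells (Homo sapiens) for antiproliferative activity, read by MTT assay (a lower number here means a stronger inhibitor, a higher number a weaker inhibitor), the lowest of the two numbers recorded; compound 1 `Cc1ccc(NC(=O)Nc2cccc(CNc3ncnc4ccccc34)c2)cc1` gives 24900 nM in this assay, a gap within the scatter, so no order between the two is claimed. Among the compounds with values here, no single-point step between measured compounds exists. Compound 3 `COc1cc2ncnc(NCc3cccc(NC(=O)Nc4ccc(Cl)cc4)c3)c2cc1OC` differs from compound 2 by chloro in place of methoxy on an aromatic carbon. Within the data shown here, with no measured precedent for this change, the step from compound 2 is expected to stay within the scatter, a 1.2-fold lower number from compound 2 to compound 3 (0.09 log units; within the scatter). Compound 3 is estimated at 20000 nM, between 8000 nM and 50000 nM.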

Compound 3, half-maximal inhibitory concentration: 30400 nM
Estimate against measurement, compound 3: 1.5-fold (0.18 log units) below, and the stated range covers the measured number.
By their numbers in this assay, from the lowest: compounds 2, 1 and 3 (each within the scatter of the next).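

Within the data shown here, exchanging 4-methoxyphenyl for 4-chlorophenyl gives a 1.2-fold higher number from compound 2 to compound 3 (0.09 log units; within the scatter) in this assay, the first single-place reading. At this aromatic carbon, para to a large group, chloro and methoxy therefore cannot be told apart in this assay. Nothing measured here bears on why this step is so small.

On these data alone, whether an amine, a carboxylic acid or a nitrile at the same carbon would move the number beyond the scatter remains open. Also open, as far as these compounds go, is whether the same exchange reads alike on the core of compound 1.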